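Compound 3 to compound 4: ethynyl replaces vinyl

The source may report more compounds than this note shows. Statements on the series, on what has been measured and on what is new or still open speak of the compounds shown alone.

In an ADME assay on Caco-2 cells (Homo sapiens) for permeability (a higher number here means that the compound crosses the layer faster, a lower number that the compound crosses the layer more slowly), compound 1 `C#CCN(CC=C)C(=O)[C@@]1(c2ccsc2)C[C@H]1CN` gives 96 nm/s and compound 2 `C=CCN(CC=C)C(=O)[C@@]1(c2ccsc2)C[C@H]1CN` gives 95 nm/s. Compound 3 `C=CCN(CCOC)C(=O)[C@@]1(c2ccsc2)C[C@H]1CN` gives 24 nm/s, the lowest of the three numbers, as shown by a 4.0-fold lower number from compound 1 to compound 3 (0.60 log units; beyond the scatter) and by a 4.0-fold lower number from compound 2 to compound 3 (0.60 log units; beyond the scatter). Compound 4 `C#CCN(CCOC)C(=O)[C@@]1(c2ccsc2)C[C@H]1CN` has not yet been measured and differs from compound 3 in one place: ethynyl in place of vinyl on a saturated chain carbon bound to an amide-type nitrogen. In words, this is ethynyl in place of vinyl on a saturated chain carbon bound to an amide-type nitrogen. The measured step closest to this change is the same exchange in the opposite direction, a 1.0-fold lower number from compound 1 to compound 2 (0.00 log units; within the scatter). Within the data shown here, that pair lacks the methoxymethyl group of compound 3, and no measured pair tests the exchange with that group present. On this single precedent, no step beyond the scatter is expected in this assay. The expected step is a 1.0-fold higher number from compound 3 to compound 4 (0.02 log units; within the scatter). Compound 4 is estimated at 25 nm/s, with an expected range of 13 nm/s to 46 nm/s.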

Compound 4, apparent permeability: 32 nm/s
Compound 4: the middle estimate sits 1.3-fold (0.11 log units) below what was measured; low and high end bracket the measured number.
By their numbers in this assay, from the lowest: compounds 3 and 4 (each within the scatter of the next); then compounds 2 and 1 (each within the scatter of the next).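

In this assay, ethynyl in place of vinyl now has a reading with the methoxymethyl group present, a 1.3-fold higher number from compound 3 to compound 4 (0.12 log units; within the scatter), and this agrees with the reading taken without that group: the same change on two cores in this assay, a 1.0-fold lower number (0.00 log units; within the scatter) from compound 1 to compound 2 and a 1.3-fold lower number (0.12 log units; within the scatter) from compound 4 to compound 3, 1.3-fold (0.12 log units) apart, within the scatter of two such steps. The lower number that came with methoxymethyl in place of vinyl also holds with ethynyl present instead of vinyl, a 3.0-fold lower number from compound 1 to compound 4 (0.48 log units; beyond the scatter), and the two steps agree in size: the same change on two cores in this assay, a 4.0-fold lower number (0.60 log units; beyond the scatter) from compound 2 to compound 3 and a 3.0-fold lower number (0.48 log units; beyond the scatter) from compound 1 to compound 4, 1.3-fold (0.12 log units) apart, within the scatter of two such steps. Across these four compounds, only the exchanges that bring in methoxymethyl move the number beyond the scatter, and none of the four goes against this.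

The compounds shown leave open how a nitrile or a longer chain on a saturated chain carbon bound to an amide-type nitrogen would read in this assay, and whether a hydroxyl in place of methoxymethyl would give a similar step. They also leave open whether these steps keep their size on a different core.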